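This account rests on a few compounds, and the source may have more. Where it says the series, first, only, none or still open, it means among the compounds named here.

Measured so far in a physicochemical assay for lipophilicity, at pH 7.4; a higher number here means a more lipophilic compound, a lower number a more polar compound (a short series sharing one core):

compound 1 `O=C(NC1CC1)C1CCN(c2cnccc2-c2ccccn2)CC1` gives 1.3
compound 2 `CCNC(=O)C1CCN(c2cncnc2-c2ccccc2)CC1` gives 1.8
compound 3 `CN(C)C(=O)C1CCN(c2cnccc2-c2ccccn2)CC1` gives 1.2

Compound 3 (1.2) sits within the scatter of compound 1, while compound 2 reads higher than compound 3, beyond the scatter.

The next compound to be measured is compound 4 (`CN(C)C(=O)C1CCN(c2cnccc2-n2cc(Br)cn2)CC1`). It carries 4-bromo-1H-pyrazol-1-yl in place of pyridin-2-yl on an aromatic carbon of a six-membered aromatic ring with 1 nitrogen, ortho to a large group and opposite the ring nitrogen (4-bromo-1H-pyrazol-1-yl in place of pyridin-2-yl on an aromatic carbon).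

Going by the values given here, only one step has been measured (a number 0.10 log units lower from compound 1 to compound 3 (within the scatter)). It lies within the scatter and concerns the group on the carbonyl carbon, not the place changed here, so it gives no size for this exchange. Among the compounds with values here, no measured step covers this place, which leaves the structural change as the only guide. A rise in this assay beyond the scatter is therefore expected, as a judgement and with a wide margin. The estimated step is a number 0.80 log units higher from compound 3 to compound 4 (beyond the scatter). Within the data shown here, no pair of compounds supports this estimate directly. Compound 4 is estimated at 2 (expected range 1.5 to 2.5).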

Compound 4, distribution coefficient: 2.1
The estimate for compound 4 lay 0.10 log units below the measured number; the measured number falls inside the stated range.
By their numbers in this assay, from the lowest: compounds 3 and 1 (each within the scatter of the next); then compounds 2 and 4 (each within the scatter of the next).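

In this assay, the place on an aromatic carbon of the six-membered aromatic ring with 1 nitrogen, ortho to a large group and opposite the ring nitrogen, now has a measured step: 4-bromo-1H-pyrazol-1-yl in place of pyridin-2-yl gives a number 0.90 log units higher from compound 3 to compound 4 (beyond the scatter). Going by these compounds alone, the only earlier step, a number 0.10 log units lower from compound 1 to compound 3 (within the scatter), concerned the group on the carbonyl carbon, and this exchange is the first to give a step beyond the scatter. Both groups have 6 heavy atoms and no net charge, so the step occurs without a change in either count, while the ring size, the hetero atoms and the hydrogen-bond acceptor count all differ; no measurement shown gives a cause for it.

The five-membered ring and the bromine enter together, and the compounds shown do not separate their contributions; a 1H-pyrazol-1-yl group without the bromine, or one with a nitrile or an amine in its place, would do so. Going by these compounds, it also remains open whether the exchange gives a step of similar size with cyclopropylamino in place of dimethylamino on the carbonyl carbon.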